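Triazole aryl swap on a spiro scaffold: weak throughout

The source may report more compounds than this note shows. Statements on the series, on what has been measured and on what is new or still open speak of the compounds shown alone.

Compound 1 `N#CC1=C(N)Oc2c(c3nc4ccccc4nc3c3ccccc23)C12C(=O)N(Cc1cnnn1-c1ccc(Cl)cc1)c1ccccc12` in a functional assay on HepG2 cells (Homo sapiens) for antiproliferative activity, read by MTT assay, with a stated time of 48 h (a higher number here means a weaker inhibitor, a lower number a stronger inhibitor), gives > 50000 nM, which is a limit of the assay rather than a number.
Compound 2 `N#CC1=C(N)Oc2c(c3nc4ccccc4nc3c3ccccc23)C12C(=O)N(Cc1cnnn1-c1ccc(Br)cc1)c1ccccc12` in this assay gives > 50000 nM, again only a limit.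
Compound 3 `N#CC1=C(N)Oc2c(c3nc4ccccc4nc3c3ccccc23)C12C(=O)N(Cc1cnnn1-c1cccc(Br)c1)c1ccccc12` in this assay gives > 50000 nM, again only a limit.

Compound 2 therefore stands at a limit, and the two other values shown are limits as well, so none of these three compounds can be ranked against the others. The steps between them, a step that the two limits leave unreadable from compound 1 to compound 2, a step that the two limits leave unreadable from compound 1 to compound 3 and a step that the two limits leave unreadable from compound 2 to compound 3, cannot be read in size because both ends sit at a limit. the limit of > 50000 nM in this assay, at which 3 of the 3 values shown sit, is all that these measurements reveal.

Compound 4 `Cc1ccc(-n2nncc2CN2C(=O)C3(C(C#N)=C(N)Oc4c3c3nc5ccccc5nc3c3ccccc43)c3ccccc32)cc1Cl` differs from compound 2 by 3-chloro-4-methylphenyl in place of 4-bromophenyl on an aromatic nitrogen. Among the measured compounds shown here, the steps that bear on this change are the three among the measured compounds, and every one of them is unreadable, so neither a direction nor a size can be drawn from them; what they do show is that changing the halophenyl on the aromatic nitrogen has so far never brought activity inside the measurable range. No step beyond the scatter is expected in this assay, and the expected step that the limit leaves unreadable from compound 2 to compound 4 is set near zero. Compound 4 is estimated at 60000 nM, between 20000 nM and 200000 nM, most likely reported once more as a limit only.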

Compound 4, half-maximal inhibitory concentration: > 50000 nM
Compound 4: only a limit was reported; the forecaster's own chance of this, stated with the estimate: 85%; the middle value is on the limit's open side.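

Compound 4 ends at a limit, as do compound 1, compound 2 and compound 3, so none of the steps from those three to compound 4 can be read in size: the limit of > 50000 nM in this assay, at which 4 of the 4 values shown sit.

The compounds shown leave open how these four rank against one another, and whether any substituted phenyl on the aromatic nitrogen brings activity within the measurable range.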